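A chloro group removed from compound 2

A few compounds are considered here, and "the series" means these few. Any claim that something is new, unique, unknown or untested is made for them only; others in the source may bear on it.

Measured so far in a functional assay on A549 cells (Homo sapiens) for inhibition, read by CCK-8 assay, with a stated time of 72 h, tested at 10 uM; a higher number here means more inhibition of growth at the concentration tested, a lower number less inhibition of growth
Compound 1 `CN(C)C(=O)c1cc2cnc(Nc3ccc(NC(=O)C4(C(=O)Nc5cccc(Cl)c5)CC4)cc3)nc2n1C1CCCC1` gives 90.7%
Compound 2 `CN(C)C(=O)c1cc2cnc(Nc3ccc(NC(=O)C4(C(=O)Nc5ccc(Cl)c(C(F)(F)F)c5)CC4)cc3)nc2n1C1CCCC1` gives 88.1%

Among the compounds with values here, compound 2 (88.1%) lies within the scatter of compound 1 (90.7%) in this assay so far. Compound 3 `CN(C)C(=O)c1cc2cnc(Nc3ccc(NC(=O)C4(C(=O)Nc5cccc(C(F)(F)F)c5)CC4)cc3)nc2n1C1CCCC1` differs from compound 2 at a single place hydrogen in place of chloro on an aromatic carbon with hydrogen in place of chloro on an aromatic carbon. Within the data shown here, one measured step bears on this aryl group: the step of a number 2.6 percentage points lower from compound 1 to compound 2 (within the scatter) stays within the scatter, and it puts 4-chloro-3-(trifluoromethyl)phenyl in place of 3-chlorophenyl on an amide-type nitrogen. Among the measured compounds shown here, no measured step removes the chloro alone. For the measured compounds named here, with only the step of a number 2.6 percentage points lower from compound 1 to compound 2 (within the scatter) to go on, no change beyond the scatter is expected in this assay for compound 3. The expected step is a number 1.1 percentage points lower from compound 2 to compound 3 (within the scatter) as an estimate. Compound 3 is expected to give 87% with an estimated range from 77% to 95% in this measurement.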

Compound 3, percent growth inhibition at one concentration: 89.2%
Compound 3: middle estimate off by 2.2 percentage points, on the low side; the measured number falls inside the stated range.
By their numbers in this assay, from the lowest: compounds 2, 3 and 1 (each within the scatter of the next).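

In this assay, within the data shown here, hydrogen in place of chloro on the aromatic carbon ortho to the trifluoromethyl group gives a number 1.1 percentage points higher from compound 2 to compound 3 (within the scatter) as the first reading of this chloro group on its own, and the change stays within the scatter. Trifluoromethyl in place of chloro on an aromatic carbon gives a number 1.5 percentage points lower from compound 1 to compound 3 (within the scatter) and also stays within the scatter, so these three aryl groups on the amide-type nitrogen cannot be told apart at this one concentration. Nothing measured here explains this lack of a difference.

All three numbers lie close together at a single concentration, so any difference among these compounds that this read-out cannot resolve remains open. As far as these compounds go, it also remains open whether an amine or a carboxylic acid on this aromatic ring would leave growth inhibition within the same scatter.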